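Replacing 2,6-dimethoxyphenyl with 2,4-dichlorophenyl: an expected step

A few compounds are considered here, and "the series" means these few. Any claim that something is new, unique, unknown or untested is made for them only; others in the source may bear on it.

- Compound 1 `O=C(Cc1csc2nc(-c3ccc(Br)cc3)cn12)N/N=C/c1ccccc1` gives 25700 nM
- Compound 2 `COc1cccc(OC)c1/C=N/NC(=O)Cc1csc2nc(-c3ccc(Br)cc3)cn12` gives 34700 nM

In a functional assay on ACHN cells (Homo sapiens) for inhibition, read by sulforhodamine B assay, with a stated time of 48 h (on this read-out higher numbers stand for weaker inhibition of growth and lower numbers for stronger inhibition of growth), compound 2 gives 34700 nM and so lies within the scatter of compound 1. Going to compound 3 `O=C(Cc1csc2nc(-c3ccc(Br)cc3)cn12)N/N=C/c1ccc(Cl)cc1Cl` the change is 2,4-dichlorophenyl in place of 2,6-dimethoxyphenyl on a carbon with a double bond to nitrogen and in short it puts 2,4-dichlorophenyl in place of 2,6-dimethoxyphenyl on a carbon with a double bond to nitrogen. Within the data shown here, the one measured step at that place is a 1.4-fold higher number from compound 1 to compound 2 (0.13 log units; within the scatter) and it stays within the scatter. Among the measured compounds shown here, with only that step to go on, no step beyond the scatter is expected in this assay and no direction can be given. The expected step is a 1.2-fold lower number from compound 2 to compound 3 (0.06 log units; within the scatter) as estimated here. For compound 3 the estimated value is 30000 nM with an expected range from 14000 nM to 62000 nM in this estimate.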

Compound 3, concentration for total growth inhibition: 53700 nM
Compound 3: the middle estimate sits 1.8-fold (0.25 log units) below what was measured; low and high end bracket the measured number.
By their numbers in this assay, from the lowest: compounds 1, 2 and 3 (each within the scatter of the next, the first and the last beyond it).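

In this assay the place on a carbon with a double bond to nitrogen now gives its first step beyond the scatter: 2,4-dichlorophenyl in place of phenyl brings a 2.1-fold higher number from compound 1 to compound 3 (0.32 log units; beyond the scatter) and so modestly weaker inhibition of growth. The exchange of 2,6-dimethoxyphenyl for 2,4-dichlorophenyl brings a 1.5-fold higher number from compound 2 to compound 3 (0.19 log units; within the scatter) and leaves those two groups indistinguishable here. Nothing available bears on the reason for this result.

On these data alone, it remains open how a phenyl carrying an amine or a carboxylic acid at this place would behave, and in which direction its number would move.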